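This account rests on a few compounds, and the source may have more. Where it says the series, first, only, none or still open, it means among the compounds named here.

Compounds measured in a functional assay on HeLa cells (Homo sapiens) for cytotoxicity, read by CCK-8 assay, with a stated time of 24 h; on this read-out higher numbers stand for weaker inhibition and lower numbers for stronger inhibition:
- compound 1, `C/C(=C\c1cc(-c2ccc(C)cc2)cs1)C(N)=O`: > 50000 nM, a limit of the assay
- compound 2, `C/C(=C\c1cc(-c2ccc(C(F)(F)F)cc2)cs1)C(N)=O`: > 50000 nM, a limit of the assay

Compound 2, with the structure `C/C(=C\c1cc(-c2ccc(C(F)(F)F)cc2)cs1)C(N)=O`, gives in this assay only > 50000 nM, which is a limit of the assay and not a number. Compound 3, `C/C(=C\c1cc(-c2ccc(Cl)cc2)cs1)C(N)=O`, is not yet measured; it differs from compound 2 by chloro in place of trifluoromethyl on an aromatic carbon. For the measured compounds named here, only one measured step bears on this change, a step that the two limits leave unreadable from compound 1 to compound 2, and its size cannot be read because of the limit of > 50000 nM in this assay, at which 2 of the 2 values shown sit. No readable step therefore tells how the substituent on this aromatic carbon moves the read-out. Compound 3 is accordingly expected to sit where compound 2 sits, most likely again at a limit, so that the step that the limit leaves unreadable from compound 2 to compound 3 is expected to be none beyond the scatter. The estimated value for compound 3 in this assay is 80000 nM, with a range from 20000 nM to 300000 nM.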

Compound 3, half-maximal inhibitory concentration: > 50000 nM
Compound 3 ended at the assay's limit (the forecaster's own chance of this, stated with the estimate: 85%); the middle value does not contradict the limit.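

No step between compound 1, compound 2 and compound 3 can be read, because each result is a limit of the assay and not a number: the limit of > 50000 nM in this assay, at which 3 of the 3 values shown sit.

The compounds shown leave open whether methyl, trifluoromethyl or chloro on this aromatic carbon differ in their effect on the read-out at all.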